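Replacing chloro with an amino group: what to expect

The source may report more compounds than this note shows. Statements on the series, on what has been measured and on what is new or still open speak of the compounds shown alone.

Compound 1 `COc1ccc(COc2ccc(OCCOCCNC3CCCC3)cc2)cc1` gives 15700 nM
Compound 2 `Clc1ccc(COc2ccc(OCCOCCNC3CCCC3)cc2)cc1` gives 7670 nM

Both numbers come from a functional assay on SK-OV-3 cells (Homo sapiens) for inhibition, read by CCK-8 assay, with a stated time of 70 h (a higher number here means a weaker inhibitor, a lower number a stronger inhibitor), and, of the two, compound 2 holds the lower one (7670 nM), which makes it the stronger inhibitor so far. Compound 3 `Nc1ccccc1COc1ccc(OCCOCCNC2CCCC2)cc1` has not yet been measured. It carries 2-aminophenyl in place of 4-chlorophenyl on a saturated chain carbon bound to an oxygen on an aromatic ring.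

Among the compounds with values here, only one measured step offers any guidance: a 2.0-fold lower number from compound 1 to compound 2 (0.31 log units; beyond the scatter) came with chloro in place of methoxy on an aromatic carbon. Compound 3 also loses the chloro, and compound 1, which lacks it too, stands at 15700 nM in this assay as a rough guide. Within the data shown here, no measured compound carries an amino group, so this guide is thin. A modest move toward a higher number is therefore expected, possibly no larger than the scatter. The estimated change is a 1.7-fold higher number from compound 2 to compound 3 (0.23 log units; within the scatter) in this direction. For compound 3 the estimated value is 13000 nM with an expected range from 4500 nM to 35000 nM in this assay.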

Compound 3, half-maximal inhibitory concentration: 14000 nM
The estimate for compound 3 lay 1.1-fold (0.03 log units) below the measured number, and the stated range covers the measured number.
By their numbers in this assay, from the lowest: compounds 2, 3 and 1 (each within the scatter of the next, the first and the last beyond it).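

In this assay, exchanging 4-chlorophenyl for 2-aminophenyl, which brings in a hydrogen-bond donor and a hydrogen-bond acceptor that the leaving group lacks, gives a 1.8-fold higher number from compound 2 to compound 3 (0.26 log units; within the scatter), and exchanging 4-methoxyphenyl for the same group gives a 1.1-fold lower number from compound 1 to compound 3 (0.05 log units; within the scatter). Compound 3 therefore cannot be told apart from either neighbour, even though compound 1 and compound 2 can be told apart from each other, so at this position the 2-aminophenyl group brings no measurable gain or loss against either earlier group. Nothing shown explains why the three numbers lie so close together.

The step also changes two things at once, the kind of group on the ring and its place on that ring, so the effect of the amino group cannot be separated from the effect of where it sits. A 4-aminophenyl group would compare directly with the 4-chlorophenyl and 4-methoxyphenyl groups, while a 2-chlorophenyl group would compare directly with 2-aminophenyl, and the compounds shown leave both comparisons open.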